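The compounds below may be only part of what the source reports. "The series", "measured", "known", "first", "only" and "open" are said of these compounds alone.

Compound 1 `CCCCOC(=O)NS(=O)(=O)c1ccc(CCC)cc1-c1ccc(Cn2c(CCCC)nc3ccccc32)cc1` and compound 2 `CCCCOC(=O)NS(=O)(=O)c1ccc(CCC)cc1-c1ccc(Cn2c(C)nc3ccccc32)cc1` share one core and differ only at a saturated chain carbon bound to an aromatic carbon of the fused two-ring system, where hydrogen stands in place of propyl. In an assay on membranes from HEK293 cells for displacement of a labelled ligand from Type-2 angiotensin II receptor (Homo sapiens), read by radioligand binding (on this read-out lower numbers stand for stronger inhibition and higher numbers for weaker inhibition), compound 1 gives 9.2 nM, and in this assay compound 2 gives 9.4 nM. Of these two numbers compound 2 holds the higher one, but the step of a 1.0-fold higher number from compound 1 to compound 2 (0.01 log units; within the scatter) shows that the two are indistinguishable within the scatter. Compound 3 `CCCCOC(=O)NS(=O)(=O)c1ccc(CCC)cc1-c1ccc(Cn2c(C3CCCC3)nc3ccccc32)cc1` is not yet measured; it differs from compound 2 by cyclopentyl in place of methyl on an aromatic carbon. Among the compounds with values here, the only measured step that bears on a change at this position, a 1.0-fold higher number from compound 1 to compound 2 (0.01 log units; within the scatter), lay within the scatter, so no step beyond the scatter is expected in this assay from this larger group. Compound 3 is therefore expected to give 9 nM, with a range from 3 nM to 30 nM. That estimate means an expected step of a 1.0-fold lower number from compound 2 to compound 3 (0.02 log units; within the scatter).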

Compound 3, inhibition constant: 35 nM
Compound 3: middle estimate off by 3.9-fold (0.59 log units), on the low side; the whole stated range lies below it.
By their numbers in this assay, from the lowest: compounds 1 and 2 (each within the scatter of the next); then compound 3.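

The earlier pair suggested that the group on this aromatic carbon hardly matters in this assay but that holds only for methyl and butyl. Cyclopentyl in place of methyl brings a 3.7-fold higher number from compound 2 to compound 3 (0.57 log units; beyond the scatter) and cyclopentyl in place of butyl brings a 3.8-fold higher number from compound 1 to compound 3 (0.58 log units; beyond the scatter) so the step is modest but of similar size from either chain. Group size alone does not sort these three compounds, as butyl stands with methyl and not with cyclopentyl.

The compounds shown leave open whether the ring itself or the branching at the attached carbon goes with the higher number, a question that isopropyl or cyclopropyl on the same carbon could address. They also leave open how an amine or a phenyl ring at this position would read. Nothing available here explains the higher number for cyclopentyl.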